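A few compounds are considered here, and "the series" means these few. Any claim that something is new, unique, unknown or untested is made for them only; others in the source may bear on it.

Measured compounds:
compound 1 (`C=C1CC(C)OC1=O`): 77400 nM in a functional assay on HL-60 cells (Homo sapiens) for cytotoxicity, read by MTT assay, with a stated time of 48 h; on this read-out lower numbers stand for stronger inhibition and higher numbers for weaker inhibition
compound 2 (`C=C1CC(CC)OC1=O`): 39500 nM in this assay

Compound 2 stands at the lowest of the two numbers in this assay; its nearest neighbour is compound 1, and the step between them, a 2.0-fold lower number from compound 1 to compound 2 (0.29 log units; within the scatter), does not exceed the scatter. Compound 3 (`C=C1CC(CCCCC)OC1=O`) is not yet measured. It differs from compound 2 by propyl in place of hydrogen on a saturated chain carbon, two bonds along the chain from a saturated ring carbon. Within the data shown here, the only measured step that bears on this change is the earlier chain lengthening, a 2.0-fold lower number from compound 1 to compound 2 (0.29 log units; within the scatter), which was small. A further lengthening of the chain is therefore expected to bring at most a modest lowering of the number in this assay, and the step is estimated as a 2.6-fold lower number from compound 2 to compound 3 (0.42 log units; beyond the scatter). On that basis compound 3 is expected to give about 15000 nM in this assay, with a range from 5000 nM to 40000 nM.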

Compound 3, half-maximal inhibitory concentration: 99400 nM
Estimate against measurement, compound 3: 6.6-fold (0.82 log units) below; the whole stated range lies below it.
By their numbers in this assay, from the lowest: compounds 2, 1 and 3 (each within the scatter of the next, the first and the last beyond it).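

Here the chain change produces its first step beyond the scatter, and it runs the other way from the earlier lengthening: propyl in place of hydrogen gives a 2.5-fold higher number from compound 2 to compound 3 (0.40 log units; beyond the scatter) in this assay. Taken across the whole series, the chain change gives a 1.3-fold higher number from compound 1 to compound 3 (0.11 log units; within the scatter), so the numbers do not separate the two compounds at the ends of this short chain series, and only compound 2 stands apart from compound 3. Nothing in the available data accounts for this reversal.

The compounds shown leave open how the number runs for chains of intermediate length, and whether a longer chain would shift it further. They also leave open what an amine or a carboxylic acid at the end of the chain would do.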